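The source may hold more compounds than are shown below. What is called first, only, known or untested is meant among the compounds shown, and "the series" means these compounds.

Compound 3 `CCC(CC)Nc1nc(Cl)nc(N[C@@H](C)c2ccccc2)n1` stands highest of the three numbers measured in an ADME assay on the whole organism for inhibition, with Echinochloa crus-galli var. formosensis as the target, with a stated time of 4 days (a lower number here means a stronger inhibitor, a higher number a weaker inhibitor), where compound 3 gives 23400 nM. Compound 1 `CC[C@H](C)Nc1nc(Cl)nc(N[C@@H](C)c2ccccc2)n1` gives 14100 nM, and compound 2 `CCCN(C)c1nc(Cl)nc(N[C@H](C)c2ccccc2)n1` gives 9770 nM. Among the compounds with values here, the only measured step that touches the same nitrogen, a 1.7-fold higher number from compound 1 to compound 3 (0.22 log units; within the scatter), shows that replacing sec-butyl with pentan-3-yl leaves the number within the scatter. Compound 4 `CCCN(C)c1nc(Cl)nc(N[C@@H](C)c2ccccc2)n1` differs from compound 3 by methyl(propyl)amino in place of (pentan-3-yl)amino on an aromatic carbon. Within the data shown here, no measured pair tests this exact exchange; compound 2, which also carries methyl(propyl)amino, gives 9770 nM, a number beyond the scatter from compound 3. A modest move toward a lower number is therefore expected, a 2.3-fold lower number from compound 3 to compound 4 (0.37 log units; beyond the scatter). Compound 4 is estimated at 10000 nM, with a likely range from 4000 nM to 25000 nM.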

Compound 4, half-maximal inhibitory concentration: 380 nM
For compound 4 the middle estimate is 26-fold (1.42 log units) above the measured one, outside the stated range (below it).
By their numbers in this assay, from the lowest: compound 4; then compounds 2, 1 and 3 (each within the scatter of the next, the first and the last beyond it).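

In this assay the amine on this aromatic carbon matters far more than the earlier pentan-3-yl step suggested: methyl(propyl)amino brings a 62-fold lower number from compound 3 to compound 4 (1.79 log units; beyond the scatter) and also a 37-fold lower number from compound 1 to compound 4 (1.57 log units; beyond the scatter) in the same configuration. Drawing the chain stereocentre S rather than R brings a 26-fold lower number from compound 2 to compound 4 (1.41 log units; beyond the scatter) with the amine unchanged. That gap can be put down to configuration alone because of one structural fact: the fact that compounds 2 and 4 differ only in the configuration as drawn.

Going by these compounds, whether dimethylamino or methyl(butyl)amino on this carbon would keep the number this low remains open.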